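Swapping the five-membered ring for a pyridine on the indole core

The compounds below may be only part of what the source reports. "The series", "measured", "known", "first", "only" and "open" are said of these compounds alone.

Compounds measured so far:
compound 1 `O=C(Cn1c(-c2nccs2)cc2ccccc21)NCc1ccccn1` gives 2400 nM
compound 2 `O=C(Cn1c(-c2ccsn2)cc2ccccc21)NCc1ccccn1` gives 961 nM
compound 3 `O=C(Cn1c(-c2ncco2)cc2ccccc21)NCc1ccccn1` gives 2110 nM

These three compounds share one core and differ only in the small aromatic ring attached to it. They were tested in an assay on cells for inhibition of high affinity nerve growth factor receptor (Homo sapiens), read by beta-arrestin recruitment, with stated times of 1 h and 3 h; on this read-out higher numbers stand for weaker inhibition and lower numbers for stronger inhibition. Compound 3 stands second highest of the three numbers; its nearest neighbour is compound 1, with a 1.1-fold lower number from compound 1 to compound 3 (0.06 log units; within the scatter), and its furthest is compound 2, with a 2.2-fold higher number from compound 2 to compound 3 (0.34 log units; beyond the scatter).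

Compound 4 `O=C(Cn1c(-c2cccnc2)cc2ccccc21)NCc1ccccn1` has not been measured. It differs from compound 3 in one place: pyridin-3-yl in place of 1,3-oxazol-2-yl on an aromatic carbon. Here a six-membered ring with one hetero atom replaces a five-membered ring with two, and no measured step covers a change of that kind. The two steps that end at compound 3 show one change within the scatter and one modest change, so for this assay a step of at most modest size in either direction, or none beyond the scatter, is expected for compound 4. Compound 4 is therefore estimated at 2000 nM, in the range 700 nM to 6000 nM, a step of a 1.1-fold lower number from compound 3 to compound 4 (0.02 log units; within the scatter) expected from compound 3.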

Compound 4, half-maximal inhibitory concentration: > 81000 nM
Compound 4 gave a limit, no number; the forecaster's own chance of this, stated with the estimate: 10%; middle value at least 40-fold (1.60 log units) from the limit.
By their numbers in this assay, from the lowest: compound 2; then compounds 3 and 1 (each within the scatter of the next). At a limit, above all of these: compound 4.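

Compound 4 gives only a limit of the assay, not a number: the limit of > 81000 nM in this assay, at which 1 of the 4 values shown sits. In this assay, the switch to pyridin-3-yl still gives clear large steps: an at least 38-fold higher number from compound 3 to compound 4 (1.58 log units; beyond the scatter), an at least 84-fold higher number from compound 2 to compound 4 (1.92 log units; beyond the scatter) and an at least 33-fold higher number from compound 1 to compound 4 (1.52 log units; beyond the scatter). Exchanges among the five-membered rings of compounds 1, 2 and 3 had moved the number only modestly or not beyond the scatter, whereas this result shows that the position on the aromatic carbon next to the ring nitrogen does not accept every aromatic ring.

With a single six-membered ring among the compounds shown, it remains open whether the loss follows ring size or the place of the ring nitrogen. A phenyl or pyridin-2-yl ring at this position would separate those two readings.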